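This account rests on a few compounds, and the source may have more. Where it says the series, first, only, none or still open, it means among the compounds named here.

Measured compounds in a functional assay on SAOS-2 cells (Homo sapiens) for inhibition, read by CCK-8 assay, with a stated time of 72 h, tested at 20 uM; on this read-out higher numbers stand for more inhibition of growth at the one concentration tested and lower numbers for less inhibition of growth:
- compound 1 `CC(C)(C)OC(=O)/C=C1/C(=O)Nc2ccccc21`: 83.3%
- compound 2 `CCCCc1ccc2c(c1)/C(=C\C(=O)OC(C)(C)C)C(=O)N2`: 84.2%
- compound 3 `COc1ccc2c(c1)NC(=O)/C2=C/C(=O)OC(C)(C)C`: 83.2%

Compound 1 stands second highest of the three numbers, with the closest neighbour being compound 3 at a number 0.1 percentage points lower from compound 1 to compound 3 (within the scatter) and the furthest being compound 2 at a number 0.9 percentage points higher from compound 1 to compound 2 (within the scatter); both steps lie within the scatter, so the three compounds are not distinguishable on this read-out.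

Compound 4 `COc1cccc2c1NC(=O)/C2=C/C(=O)OC(C)(C)C` differs from compound 1 by methoxy in place of hydrogen on an aromatic carbon. The two steps that bear on this change are the substitutions on the aromatic carbons of the shared core: the butyl in compound 2, giving a number 0.9 percentage points higher from compound 1 to compound 2 (within the scatter), and the methoxy in compound 3, giving a number 0.1 percentage points lower from compound 1 to compound 3 (within the scatter). Neither substitution moves the number beyond the scatter. A methoxy at a different aromatic carbon is therefore expected to leave the read-out flat as well, that is, no step beyond the scatter in this assay is expected.

Compound 4 is accordingly estimated at 83%, with a range of 73% to 91%, which means an expected step of a number 0.3 percentage points lower from compound 1 to compound 4 (within the scatter).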

Compound 4, percent growth inhibition at one concentration: 81.1%
For compound 4 the middle estimate is 1.9 percentage points above the measured one; measured number inside the range.
By their numbers in this assay, from the lowest: compounds 4, 3, 1 and 2 (each within the scatter of the next).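

In this assay, methoxy on this aromatic carbon, ortho to a fused ring and meta to a fused ring, gives a number 2.2 percentage points lower from compound 1 to compound 4 (within the scatter) and so adds a third substituted compound with no step beyond the scatter. Methoxy now stands on two different aromatic carbons of the shared core, and the other placement gives a number 0.1 percentage points lower from compound 1 to compound 3 (within the scatter) on the same read-out, so neither placement separates from compound 1. Nothing available explains this flat result.

The compounds shown leave open whether an amine or a hydroxyl on this aromatic carbon would also stay within the scatter, and whether a carboxylic acid in place of the tert-butyl ester would move the number. With one concentration tested, they also leave open whether any differences exist among these compounds at lower concentrations.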